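A few compounds are considered here, and "the series" means these few. Any claim that something is new, unique, unknown or untested is made for them only; others in the source may bear on it.

Of the compounds shown here, three built on one shared core have been tested in a functional assay on MCF7 cells (Homo sapiens) for inhibition, read by MTT assay, with a stated time of 72 h (a higher number here means a weaker inhibitor, a lower number a stronger inhibitor), which measures how strongly each compound holds back the growth of breast-cancer cells. Compound 1 `COc1ccc(Nc2nc(Oc3cccc(NC(=O)/C=C/C(C)C)c3)c3sccc3n2)cc1` carries an amide built on 3-methylbut-1-en-1-yl. In this assay compound 1 gives only a limit, > 50000 nM. Compound 2 `CC(C)=CC(=O)Nc1cccc(Oc2nc(Nc3cccc(C#N)c3)nc3ccsc23)c1` carries an amide built on 2-methylprop-1-en-1-yl, and in this assay compound 2 gives 41100 nM. Compound 3 `CC/C=C/C(=O)Nc1cccc(Oc2nc(Nc3cccc(C#N)c3)nc3ccsc23)c1` carries an amide built on but-1-en-1-yl. In this assay compound 3 likewise gives only a limit, > 50000 nM. The step of an at least 1.2-fold higher number from compound 2 to compound 3 (0.08 log units; that floor lies within the scatter) therefore has a size that cannot be resolved.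

Compound 4 `CC(C)/C=C/C(=O)Nc1cccc(Oc2nc(Nc3cccc(C#N)c3)nc3ccsc23)c1` differs from compound 3 by methyl in place of hydrogen on a saturated chain carbon bound to a double-bonded chain carbon and a saturated chain carbon. Going by the values given here, the one measured step that bears on this change, an at least 1.2-fold higher number from compound 2 to compound 3 (0.08 log units; that floor lies within the scatter), is too small to read, and the limit of > 50000 nM in this assay, at which 2 of the 3 values shown sit, shows where most values sit. Compound 1 carries the same 3-methylbut-1-en-1-yl amide as compound 4, differing only at the other end of the molecule, and in this assay compound 1 gives > 50000 nM. The step that the limit leaves unreadable from compound 3 to compound 4 is therefore expected to stay within the scatter. Compound 4 is expected to sit at about 60000 nM, between 30000 nM and 150000 nM.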

Compound 4, half-maximal inhibitory concentration: > 50000 nM
Compound 4: only a limit was reported; the forecaster's own chance of this, stated with the estimate: 75%; the middle value lies beyond the limit too.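

The methyl on this saturated chain carbon brings no readable change in this assay: the steps to compound 4 from compound 3 and from compound 1 cannot be read, as each joins two limits. Going by these compounds alone, the 3-methylbut-1-en-1-yl amide now gives a limit with either 4-methoxyphenyl or 3-cyanophenyl on the nitrogen, and the one step with a printed floor, an at least 1.2-fold higher number from compound 2 to compound 4 (0.08 log units; that floor lies within the scatter), does not separate this amide from the 2-methylprop-1-en-1-yl amide. The series now mostly rests at a single ceiling: the limit of > 50000 nM in this assay, at which 3 of the 4 values shown sit.

On these data alone, whether an amine or a hydroxyl on this saturated chain carbon, in place of methyl, would give a measurable value remains open. So does the effect of a longer chain, and with only compound 2 giving a number, the true order of these amides cannot be told.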